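This account rests on a few compounds, and the source may have more. Where it says the series, first, only, none or still open, it means among the compounds named here.

Among the measured compounds shown here, only two compounds have been measured so far in a functional assay on THP-1 cells (Homo sapiens) for inhibition, read by sulforhodamine B assay, with a stated time of 48 h, tested at 50 uM; a lower number here means less inhibition of growth, a higher number more inhibition of growth at the concentration tested. Compound 1 (`COc1ccc(/C=C/C(=O)/C=C/c2ccc(OCc3cn(CCCCCOc4cc(=O)oc5ccccc45)nn3)c(OC)c2)cc1OC`) gives 47%, the lower of the two numbers. Compound 2 (`COc1cc(/C=C/C(=O)/C=C/c2cccs2)ccc1OCc1cn(CCOc2cc(=O)oc3ccccc23)nn1`) gives 76%, a gap beyond the usual scatter. However, compound 2 differs from compound 1 in more than one place, so that gap says little about any single change.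

Compound 3 (`COc1cccc(/C=C/C(=O)/C=C/c2ccc(OCc3cn(CCCCCOc4cc(=O)oc5ccccc45)nn3)c(OC)c2)c1`) is closer to compound 1: hydrogen stands in place of methoxy on an aromatic carbon, turning 3,4-dimethoxyphenyl into 3-methoxyphenyl (hydrogen in place of methoxy on an aromatic carbon). For the measured compounds named here, no measured pair shows what this one change does, so the expectation is only tentative: a small step within the scatter, with no firm direction. The estimated step of a number 3 percentage points higher from compound 1 to compound 3 (within the scatter) reflects this. For compound 3 the expected value is 50%, with an estimated range from 30% to 72%.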

Compound 3, percent growth inhibition at one concentration: 37%
For compound 3 the middle estimate is 13 percentage points above the measured one; the range from low to high includes it.
By their numbers in this assay, from the lowest: compounds 3 and 1 (each within the scatter of the next); then compound 2.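

In this assay, hydrogen in place of methoxy on this aromatic carbon gives a number 10 percentage points lower from compound 1 to compound 3 (within the scatter). Among the compounds shown here, this is the first pair that differs in only one place, and it shows no clear effect of the change: turning 3,4-dimethoxyphenyl into 3-methoxyphenyl leaves a reading that cannot be told apart from that of compound 1, so this methoxy group is not needed for the growth inhibition seen at the concentration tested. Nothing at hand explains this result.

Still open, on these data alone, is whether a different group on the same carbon, such as an amine or a carboxylic acid, would move the number beyond the scatter. Also open, as far as these compounds go, is which of the several differences in compound 2 goes with its higher number.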